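This account rests on a few compounds, and the source may have more. Where it says the series, first, only, none or still open, it means among the compounds named here.

Measured compounds:
Compound 1 `CC(C)(C)c1cn(C[C@H](O)[C@H]2OC(=O)C(OCc3ccccc3)=C2OCc2ccccc2)nn1` gives 730 nM in a functional assay on MCF7 cells (Homo sapiens) for antiproliferative activity, read by MTT assay, with a stated time of 72 h; on this read-out lower numbers stand for stronger inhibition and higher numbers for weaker inhibition.
Compound 2 `O=C1O[C@H]([C@@H](O)Cn2cc(-c3cccc(O)c3)nn2)C(OCc2ccccc2)=C1OCc1ccccc1` gives 51800 nM in this assay.
Compound 3 `COc1ccc(-c2cn(C[C@H](O)[C@H]3OC(=O)C(OCc4ccccc4)=C3OCc3ccccc3)nn2)cc1` gives 99700 nM in this assay.

Compound 3 holds the highest of the three numbers, yet its distance from compound 2 is a 1.9-fold higher number from compound 2 to compound 3 (0.28 log units; within the scatter), so the two cannot be set in order; only compound 1 stands clearly apart, as a 140-fold higher number from compound 1 to compound 3 (2.14 log units; beyond the scatter) shows.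

Compound 4 `CCCCCc1ccc(-c2cn(C[C@H](O)[C@H]3OC(=O)C(OCc4ccccc4)=C3OCc3ccccc3)nn2)cc1` is not yet measured. It differs from compound 3 in one place: pentyl in place of methoxy on an aromatic carbon.

Going by the values given here, no measured step exchanges one group on that aromatic carbon for another chain of this kind. Among the compounds with values here, the steps that bear on compound 4 are indirect: a 71-fold higher number from compound 1 to compound 2 (1.85 log units; beyond the scatter) and a 140-fold higher number from compound 1 to compound 3 (2.14 log units; beyond the scatter) show that both aryl-bearing compounds fall far below the tert-butyl compound 1, while a 1.9-fold higher number from compound 2 to compound 3 (0.28 log units; within the scatter) shows that swapping one substituted phenyl for another changed little. Compound 4 keeps the phenyl of compound 3, so the expected step is small and of uncertain direction, a 1.7-fold lower number from compound 3 to compound 4 (0.22 log units; within the scatter).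

Compound 4 is therefore estimated at 60000 nM, within 15000 nM to 200000 nM.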

Compound 4, half-maximal inhibitory concentration: 9010 nM
The estimate for compound 4 lay 6.7-fold (0.82 log units) above the measured number; the whole stated range lies above it.
By their numbers in this assay, from the lowest: compound 1; then compound 4; then compounds 2 and 3 (each within the scatter of the next).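

In this assay the group on the phenyl is not a matter of indifference: pentyl in place of methoxy on the aromatic carbon para to a large group gives an 11-fold lower number from compound 3 to compound 4 (1.04 log units; beyond the scatter), whereas the earlier exchange of one substituted phenyl for another stayed within the scatter. The 4-pentylphenyl group also stands clear of 3-hydroxyphenyl, at a 5.7-fold lower number from compound 2 to compound 4 (0.76 log units; beyond the scatter), yet it does not recover what tert-butyl gives, as a 12-fold higher number from compound 1 to compound 4 (1.09 log units; beyond the scatter) shows. Nothing available explains these differences.

The compounds shown leave open whether a shorter chain such as propyl or a longer one such as heptyl on this carbon would give a lower or a higher number than pentyl. On these data alone, how an amine or a carboxylic acid in place of pentyl would read also remains open.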